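Triazole amide series: trifluoromethyl added to the benzyl arm

The source may hold more compounds than are shown below. What is called first, only, known or untested is meant among the compounds shown, and "the series" means these compounds.

Measured so far, in a functional assay on HepG2 cells (Homo sapiens) for inhibition, read by MTT assay, with a stated time of 72 h; a higher number here means a weaker inhibitor, a lower number a stronger inhibitor:
compound 1 `CC(C)n1ncc2c(C(=O)NCc3cn(-c4ccccc4)nn3)cccc21` gives > 40000 nM, which is a limit of the assay and not a number.
compound 2 `CC(C)n1ncc2c(C(=O)NCc3cn(-c4ccc(C(F)(F)F)cc4)nn3)cccc21` gives > 40000 nM, again a limit of the assay.
compound 3 `CC(C)n1ncc2c(C(=O)NCc3cn(Cc4ccccc4)nn3)cccc21` gives 13700 nM, the only number in the set.

Compound 4 `CC(C)n1ncc2c(C(=O)NCc3cn(Cc4ccc(C(F)(F)F)cc4)nn3)cccc21` has not been measured in this assay. It differs from compound 3 by trifluoromethyl in place of hydrogen on an aromatic carbon. The same change has been made once before, from compound 1 to compound 2, (trifluoromethyl in place of hydrogen on an aromatic carbon), and there its step was a step that the two limits leave unreadable from compound 1 to compound 2, since both values sit at the limit of > 40000 nM in this assay, at which 2 of the 3 values shown sit. The two cores on which this change is made differ by benzyl in place of phenyl on an aromatic nitrogen; the place of the trifluoromethyl is described in the same words for both pairs.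

Of the cores themselves: the step of an at least 2.9-fold lower number from compound 1 to compound 3 (0.46 log units; beyond the scatter) and the step of an at least 2.9-fold lower number from compound 2 to compound 3 (0.46 log units; beyond the scatter) both put the benzyl compound on the readable side, whereas the phenyl compounds give only limits.

For the measured compounds named here, the one earlier instance of the change is therefore uninformative for its size, and the remaining data concern a different core. The expectation for compound 4 is a step of roughly a 1.0-fold higher number from compound 3 to compound 4 (0.01 log units; within the scatter), that is, little change from compound 3. For compound 4 the estimated value in this assay is 14000 nM, expected to lie between 4000 nM and 40000 nM, with a real chance that only a limit is returned.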

Compound 4, half-maximal inhibitory concentration: > 40000 nM
Compound 4: no number, only a limit; the forecaster's own chance of this, stated with the estimate: 35%; at least 2.8-fold (0.45 log units) between middle value and limit.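

In this assay, trifluoromethyl in place of hydrogen on the benzyl arm gives an at least 2.9-fold higher number from compound 3 to compound 4 (0.46 log units; beyond the scatter), so on the benzyl core this change moves inhibition to the weaker side, with the full size of the step unknown since compound 4 returns only a limit. The same change on the phenyl core, from compound 1 to compound 2, cannot be read, so this series shows neither that the effect of the change carries from one core to the other nor that it fails to, and one readable pair supports no rule for the series. Only compound 3 now holds a number, and every other value shown is a limit: the limit of > 40000 nM in this assay, at which 3 of the 4 values shown sit.

The compounds shown leave open whether a different group in the place the trifluoromethyl holds on the benzyl arm, such as an amine or a carboxylic acid, would keep a readable number in this assay. Also open, as far as these compounds go, is whether a longer chain, such as phenylethyl, in place of benzyl on the aromatic nitrogen would go further than the step seen with benzyl, an at least 2.9-fold lower number from compound 1 to compound 3 (0.46 log units; beyond the scatter).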